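This account rests on a few compounds, and the source may have more. Where it says the series, first, only, none or still open, it means among the compounds named here.

Compound 1 `COc1cc(C(=O)N2CCC(C)(C)C2)cc2nc(NCc3cccc(Cl)c3)oc12` has no result of its own in an ADME assay on Caco-2 cells (Homo sapiens) for permeability, read by LC-MS, in the apical to basolateral direction, with a stated time of 2 h; on this read-out lower numbers stand for lower permeability and higher numbers for higher permeability; in this assay compound 1 gives "not determined" (no result reported). The one measured point in this assay is compound 2 `COc1cc(C(=O)N2CCC(O)C(C)C2)cc2nc(NCc3cc(Cl)ccn3)oc12`, a near relative, for which compound 2 gives 41 nm/s. Compound 3 `COc1cc(C(=O)N2CC(C)C(O)CC2C2CC2)cc2nc(NCc3cccc(Cl)c3)oc12` differs from compound 1 in one place, (2-cyclopropyl-4-hydroxy-5-methylpiperidin-1-yl in place of 3,3-dimethylpyrrolidin-1-yl on a carbonyl carbon). Among the compounds with values here, with no measured step of this kind, a downward shift in this assay beyond the usual scatter is expected on the change. Compound 3 is therefore expected to reach about 80 nm/s in this assay, within a range of 30 nm/s to 200 nm/s.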

Compound 3, apparent permeability: 138 nm/s
The estimate for compound 3 lay 1.7-fold (0.24 log units) below the measured number; the range from low to high includes it.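

In this assay no step can be read between compound 1 and compound 3. The compounds shown leave open how 2-cyclopropyl-4-hydroxy-5-methylpiperidin-1-yl in place of 3,3-dimethylpyrrolidin-1-yl shifts this read-out, and no evidence at hand bears on the result.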